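The source may hold more compounds than are shown below. What is called first, only, known or untested is meant among the compounds shown, and "the series" means these compounds.

The series shares one core, carried by compound 1 `COc1cc(-c2cc(C(=O)O)c3ccccc3n2)ccc1OCC(=O)Nc1ccccc1Cl`, which in an ADME assay on HaCaT cells (Homo sapiens) for inhibition (on this read-out lower numbers stand for stronger inhibition and higher numbers for weaker inhibition), gives 210000 nM. Compound 2 `COc1cc(-c2cc(C(=O)O)c3ccccc3n2)ccc1OCC(=O)Nc1ccccc1C(F)(F)F` gives 102000 nM in this assay, and compound 3 `COc1cc(-c2cc(C(=O)O)c3ccccc3n2)ccc1OCC(=O)Nc1cccc(C(F)(F)F)c1` gives 160000 nM. Compound 3 stands second highest of the three numbers, yet it lies within the scatter of compound 1 and within the scatter of compound 2, so no order among these three can be claimed. The unmeasured compound 4 `CCCCCCNC(=O)COc1ccc(-c2cc(C(=O)O)c3ccccc3n2)cc1OC` differs from compound 3 by hexyl in place of 3-(trifluoromethyl)phenyl on an amide-type nitrogen. Within the data shown here, no measured step replaces the aromatic part on the amide nitrogen with a chain, so the measured steps touch this change only loosely: a 2.1-fold lower number from compound 1 to compound 2 (0.31 log units; beyond the scatter) was modest, while a 1.3-fold lower number from compound 1 to compound 3 (0.12 log units; within the scatter) and a 1.6-fold higher number from compound 2 to compound 3 (0.20 log units; within the scatter) stayed within the scatter. Changes on the amide nitrogen have so far moved the read-out little, and the present change is larger than any of them, which widens the uncertainty without pointing a direction. The step of a 1.1-fold lower number from compound 3 to compound 4 (0.03 log units; within the scatter) is therefore expected to stay within the scatter. The estimate for compound 4 in this assay is 150000 nM, with a range from 50000 nM to 450000 nM.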

Compound 4, half-maximal inhibitory concentration: > 300000 nM
Compound 4: a limit, no number; the forecaster's own chance of this, stated with the estimate: 25%; middle value at least 2.0-fold (0.30 log units) away from the limit.
By their numbers in this assay, from the lowest: compounds 2, 3 and 1 (each within the scatter of the next, the first and the last beyond it). At a limit, above all of these: compound 4.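

In this assay, compound 4, which carries hexyl in place of 3-(trifluoromethyl)phenyl on an amide-type nitrogen, gives a limit and not a number: the limit of > 300000 nM in this assay, at which 1 of the 4 values shown sits. This is the first chain at this position among the compounds shown, and its clearest step is an at least 2.9-fold higher number from compound 2 to compound 4 (0.46 log units; beyond the scatter), which lies beyond the scatter, while an at least 1.8-fold higher number from compound 3 to compound 4 (0.27 log units; that floor lies within the scatter) and an at least 1.4-fold higher number from compound 1 to compound 4 (0.15 log units; that floor lies within the scatter) have floors that lie within it. The earlier compounds shown here varied only the substituted phenyl group on this nitrogen, so the new result adds that a chain here gives a higher number than the compound with 2-(trifluoromethyl)phenyl, whereas its standing against the other two compounds remains unsettled.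

As far as these compounds go, the true size of all three steps stays unknown, since each is counted from a limit. From the compounds shown here alone, it also remains open how a shorter chain such as butyl, a hexyl chain ending in an amine or a carboxylic acid, or an unsubstituted phenyl on the same nitrogen would read.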